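The source may report more compounds than this note shows. Statements on the series, on what has been measured and on what is new or still open speak of the compounds shown alone.

Compound 1 `CN(c1ncnc2c1ncn2Cc1ccccc1)C1CCCC1` gives 17% in a functional assay on the whole organism for inhibition, with Rattus norvegicus as the target, in the maximal electroshock model, at a dose of 25 mg/kg by the intraperitoneal route; on this read-out higher numbers stand for more inhibition at the one dose given (going by the name of the read-out) and lower numbers for less inhibition.
Compound 2 `c1ccc(Cn2cnc3c(N4CCC4)ncnc32)cc1` gives 17%.
Compound 3 `CN(C=O)c1ncnc2c1ncn2Cc1ccccc1` gives 0%.

Compound 3 stands lowest of the three: a number 17 percentage points lower from compound 1 to compound 3 (beyond the scatter) and a number 17 percentage points lower from compound 2 to compound 3 (beyond the scatter), while no change at the digits printed from compound 1 to compound 2 (within the scatter). Compound 4 `Oc1ncnc2c1ncn2Cc1ccccc1` has not been measured; it differs from compound 3 in one place: hydroxy in place of formyl(methyl)amino on an aromatic carbon. Among the measured compounds shown here, none of the measured steps places a hydroxy on that carbon, so no step bears directly on this change; the two steps ending at compound 3 show only that its formyl(methyl)amino group goes with the lowest number seen. Compound 3 already sits at the floor of the read-out, so no drop is possible, and the data give no sign of a rise beyond the scatter; the expected step of a number 8 percentage points higher from compound 3 to compound 4 (within the scatter) is therefore small. Compound 4 is estimated at 8%, in the range 0% to 30%.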

Compound 4, a percentage reported as inhibition, in the whole organism at one dose (the size of the read-out at that dose, not a potency): 17%
Compound 4: the middle estimate sits 9 percentage points below what was measured, within the range that was stated.
By their numbers in this assay, from the lowest: compound 3; then compounds 1, 2 and 4 (each within the scatter of the next).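

The step to hydroxy on this aromatic carbon is a number 17 percentage points higher from compound 3 to compound 4 (beyond the scatter) in this assay, so the result for compound 3 does not extend to every small group placed here. Hydroxy, with its single heavy atom and no ring, also gives no change at the digits printed from compound 2 to compound 4 (within the scatter) and no change at the digits printed from compound 1 to compound 4 (within the scatter), so among these three compounds, a larger group with a ring at this carbon goes with no higher number. Nothing available explains these numbers.

Still open, on these data alone, is how a primary amine or a carboxylic acid on this carbon would read out. Also open, as far as these compounds go, is whether any group here can rise beyond the scatter of these three compounds.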